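Fluoro to Trifluoromethyl on Two Related Cores

This account rests on a few compounds, and the source may have more. Where it says the series, first, only, none or still open, it means among the compounds named here.

Measured so far in a functional assay on PC-3 cells (Homo sapiens) for cytotoxicity, read by MTT assay, with a stated time of 72 h; on this read-out lower numbers stand for stronger inhibition and higher numbers for weaker inhibition:
compound 1, `O=C(Nc1ccc(Oc2ccnc3[nH]ccc23)c(F)c1)c1nn(-c2ccc(Cl)c(F)c2)ccc1=O`, gives 13600 nM;
compound 2, `O=C(Nc1ccc(Oc2ccnc3[nH]ccc23)c(F)c1)c1nn(-c2ccc(Cl)c(C(F)(F)F)c2)ccc1=O`, gives 5500 nM;
compound 3, `Cn1ccc2c(Oc3ccc(NC(=O)c4nn(-c5ccc(Cl)c(F)c5)ccc4=O)cc3)ccnc21`, gives 32700 nM.

Compound 1 and compound 2 share one core and differ in a single place: trifluoromethyl in place of fluoro on an aromatic carbon. That change produced a 2.5-fold lower number from compound 1 to compound 2 (0.39 log units; beyond the scatter). Compound 3 is built on a different core; how the core of compound 3 differs from that of compound 1 is not broken down here. Among the three measured compounds, compound 3 carries the highest number.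

Compound 4, `Cn1ccc2c(Oc3ccc(NC(=O)c4nn(-c5ccc(Cl)c(C(F)(F)F)c5)ccc4=O)cc3)ccnc21`, has not yet been measured. It relates to compound 3 exactly as compound 2 relates to compound 1: trifluoromethyl in place of fluoro on an aromatic carbon. The surroundings of the changed position read the same in both pairs, so this is the same change made on a second core.

The step from compound 3 to compound 4 is expected to be a 2.5-fold lower number from compound 3 to compound 4 (0.40 log units; beyond the scatter), resting on the earlier step of a 2.5-fold lower number from compound 1 to compound 2 (0.39 log units; beyond the scatter), since the same change is made. Going by the values given here, only one earlier example of this change exists, and the core is different. The range is therefore kept wide. Compound 4 is expected to give about 13000 nM in this assay, most likely between 5500 nM and 30000 nM.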

Compound 4, half-maximal inhibitory concentration: 10300 nM
Compound 4: the middle estimate sits 1.3-fold (0.10 log units) above what was measured, within the range that was stated.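

Made on the second core, the swap of fluoro for trifluoromethyl in this assay gives a 3.2-fold lower number from compound 3 to compound 4 (0.50 log units; beyond the scatter). Set beside the earlier example, the change carries over from one core to the other in the same direction and with much the same size: the same change on two cores in this assay, a 2.5-fold lower number (0.39 log units; beyond the scatter) from compound 1 to compound 2 and a 3.2-fold lower number (0.50 log units; beyond the scatter) from compound 3 to compound 4, 1.3-fold (0.11 log units) apart, within the scatter of two such steps. This shows that, in these two pairs and in this one assay, going from 4-chloro-3-fluorophenyl to 4-chloro-3-(trifluoromethyl)phenyl lowers the number by a similar amount on either core, but two pairs cannot show that the same would hold on a third core, nor can they explain why the number drops.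

On these data alone, only fluoro and trifluoromethyl appear at this place on the ring, so whether a methyl group, a methoxy group or a nitrile would shift the number in the same way stays open. Also open, as far as these compounds go, is whether the step would keep its size in any test other than this assay.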